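Fluorine on the Pendant Ring, Now on the Cyclopentyl Core

The source may hold more compounds than are shown below. What is called first, only, known or untested is meant among the compounds shown, and "the series" means these compounds.

Compound 1 `CC(C)(C)S(=O)(=O)Nc1ccc(-c2c(C(N)=O)c3cc(F)c(OC(F)F)cc3n2-c2ccccc2)cc1` and compound 2 `CC(C)(C)S(=O)(=O)Nc1ccc(-c2c(C(N)=O)c3cc(F)c(OC(F)F)cc3n2-c2ccccc2)c(F)c1` share a core that bears a phenyl on its aromatic nitrogen. In an ADME assay on the whole organism (plasma, strain Sprague-Dawley) for pharmacokinetics, with Rattus norvegicus as the target, with stated times of 6 h and 30 min, at a dose of 10 mg/kg by the oral route (on this read-out lower numbers stand for lower exposure and higher numbers for higher exposure at the dose given), compound 1 gives 7670 ng.h/mL, and compound 2 gives 4360 ng.h/mL. The change between them is fluoro in place of hydrogen on an aromatic carbon, and it made a 1.8-fold lower number from compound 1 to compound 2 (0.25 log units; within the scatter). Compound 3 `CC(C)(C)S(=O)(=O)Nc1ccc(-c2c(C(N)=O)c3cc(F)c(OC(F)F)cc3n2C2CCCC2)cc1` differs from compound 1 by cyclopentyl in place of phenyl on an aromatic nitrogen; that step is a 38-fold lower number from compound 1 to compound 3 (1.58 log units; beyond the scatter). In this assay compound 3 gives 200 ng.h/mL, the lowest of the three numbers. Compound 4 `CC(C)(C)S(=O)(=O)Nc1ccc(-c2c(C(N)=O)c3cc(F)c(OC(F)F)cc3n2C2CCCC2)c(F)c1` has not yet been measured. For the measured compounds named here, it differs from compound 3 by fluoro in place of hydrogen on an aromatic carbon, the same change at the same place as the one from compound 1 to compound 2. Compound 4 is expected to make a step of a 1.5-fold lower number from compound 3 to compound 4 (0.19 log units; within the scatter), because the same change earlier made a 1.8-fold lower number from compound 1 to compound 2 (0.25 log units; within the scatter), which was within the scatter. Going by the values given here, the estimate for compound 4 in this assay is 130 ng.h/mL, expected to fall between 40 ng.h/mL and 400 ng.h/mL, with wide bounds given that only one earlier example exists.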

Compound 4, area under the concentration-time curve: 200 ng.h/mL
For compound 4 the middle estimate is 1.5-fold (0.19 log units) below the measured one; low and high end bracket the measured number.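

In this assay, fluoro in place of hydrogen on an aromatic carbon carried over to the cyclopentyl core as no change at the digits printed from compound 3 to compound 4 (within the scatter), and the two readings of this change agree: the same change on two cores in this assay, a 1.8-fold lower number (0.25 log units; within the scatter) from compound 1 to compound 2 and no change at the digits printed (within the scatter) from compound 3 to compound 4, 1.8-fold (0.25 log units) apart, within the scatter of two such steps. Cyclopentyl in place of phenyl on an aromatic nitrogen remained a large step with the fluoro present, a 22-fold lower number from compound 2 to compound 4 (1.34 log units; beyond the scatter), and it too agrees with its earlier reading: the same change on two cores in this assay, a 38-fold lower number (1.58 log units; beyond the scatter) from compound 1 to compound 3 and a 22-fold lower number (1.34 log units; beyond the scatter) from compound 2 to compound 4, 1.8-fold (0.25 log units) apart, within the scatter of two such steps. Within these four compounds the two changes therefore read as independent of each other, but this rests on two cores and a single read-out, and since both fluoro steps lie within the scatter, it gives the fluoro no direction of effect and does not show that the pattern holds on other cores.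

As far as these compounds go, it remains open how a smaller group such as methyl, or another ring such as pyridyl or cyclohexyl, would behave on the aromatic nitrogen. Also open, from the compounds shown here alone, is whether chloro or methoxy on the same aromatic carbon would carry across the two cores as the fluoro does.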